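Ortho substituent swap on the acylsulfonamide aryl ring

This account rests on a few compounds, and the source may have more. Where it says the series, first, only, none or still open, it means among the compounds named here.

Measured so far:
compound 1, `COc1cc(C(=O)NS(=O)(=O)c2ccccc2Cl)ccc1Cn1ccc2ccc(NC(=O)CC3CCCC3)cc21`: 9.8
compound 2, `CCCCC(CC)C(=O)Nc1ccc2ccn(Cc3ccc(C(=O)NS(=O)(=O)c4ccccc4)cc3)c2c1`: 6.8
compound 3, `CCCCC(CC)C(=O)Nc1ccc2ccn(Cc3ccc(C(=O)NS(=O)(=O)c4ccc(C)cc4)cc3OC)c2c1`: 8.4

In a functional assay (trachea) for antagonist activity, with Cavia porcellus as the target (on this read-out higher numbers stand for higher potency (the scale is a negative logarithm) and lower numbers for lower potency), compound 1 gives 9.8 and stands highest of the three; the gaps to compound 3 and to compound 2 both lie beyond the scatter, so compound 1 is the most potent compound of the set. Within the data shown here, compound 2 and compound 3 differ from compound 1 in more than one place, so their values give no single step to lean on.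

Compound 4, `COc1cc(C(=O)NS(=O)(=O)c2ccccc2N)ccc1Cn1ccc2ccc(NC(=O)CC3CCCC3)cc21`, is not yet measured. It differs from compound 1 in one place only: amino in place of chloro on an aromatic carbon. Among the measured compounds shown here, no measured pair shows this change, so its size is not known from the series. The exchange keeps the heavy-atom count and adds one donor and one acceptor, which is the whole of what the structures tell.

Given the high starting point of compound 1, a modest move downward is expected rather than a gain, with the outcome in this assay for compound 4 estimated at 9.2, range 8.4 to 10. The estimated step of a number 0.60 log units lower from compound 1 to compound 4 (beyond the scatter) is expected to be small, possibly within the scatter.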

Compound 4, negative logarithm of the antagonist equilibrium constant: 9.9
Compound 4: middle estimate off by 0.70 log units, on the low side, within the range that was stated.
By their numbers in this assay, from the lowest: compound 2; then compound 3; then compounds 1 and 4 (each within the scatter of the next).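

Among these compounds, replacing chloro with amino, ortho to a large group on the sulfonyl-bearing ring, gives a number 0.10 log units higher from compound 1 to compound 4 (within the scatter) in this assay, the first step that isolates a single place. At the top of the measured range, compound 1 gives 9.8 and compound 4 gives 9.9, so this pair shows that 2-chlorophenyl and 2-aminophenyl cannot be told apart on this read-out, even though the amino group brings a hydrogen-bond donor and acceptor that chloro does not have. Nothing at hand accounts for the two groups reading alike, and this single pair sets no rule for other groups at this position.

Still open, as far as these compounds go, is how the same place on the core of compound 1 responds to a bare hydrogen, a methyl, a dimethylamino group or a carboxylic acid, any of which would show whether this position accepts a wider range of groups. Compound 2 and compound 3 differ from compound 1 in more than one place, so they cannot settle what the ring substituent contributes on its own.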